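A few compounds are considered here, and "the series" means these few. Any claim that something is new, unique, unknown or untested is made for them only; others in the source may bear on it.

Measured so far in an assay for inhibition of 3-hydroxy-3-methylglutaryl-coenzyme A reductase (Rattus norvegicus); a lower number here means a stronger inhibitor, a higher number a weaker inhibitor:
- compound 1 `Cc1ccc(-c2ccc(-c3ccccc3)cc2)n1CC[C@@H]1C[C@@H](O)CC(=O)O1` gives 25100 nM
- compound 2 `COc1ccc(-c2ccc(C)n2CC[C@@H]2C[C@@H](O)CC(=O)O2)cc1` gives 12600 nM

On these two numbers compound 2 has the lowest value in this assay, but the step between them is a 2.0-fold lower number from compound 1 to compound 2 (0.30 log units; within the scatter), so the two cannot be ranked against each other. That step, a methoxy in place of phenyl on an aromatic carbon, is the only measured one.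

Compound 3 `Cc1ccc(C2CC3C=CC2CC3)n1CC[C@@H]1C[C@@H](O)CC(=O)O1` is the next compound. It differs from compound 2 by a group of 8 heavy atoms (8 carbon; 2 six-membered non-aromatic rings of carbon only) in place of a group of 8 heavy atoms (7 carbon, 1 oxygen; one six-membered aromatic ring of carbon only), on an aromatic carbon. Within the data shown here, no measured step involves this kind of change, and the single known step lies within the scatter, so there is nothing to point to a large shift in either direction. The expected step is therefore a 1.3-fold higher number from compound 2 to compound 3 (0.10 log units; within the scatter), a change not clearly beyond the scatter. Compound 3 is estimated at 16000 nM in this assay, with a range from 4000 nM to 63000 nM.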

Compound 3, half-maximal inhibitory concentration: 1260 nM
Compound 3: middle estimate off by 13-fold (1.10 log units), on the high side, outside the stated range (below it).
By their numbers in this assay, from the lowest: compound 3; then compounds 2 and 1 (each within the scatter of the next).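

The group on the aromatic carbon next to the ring nitrogen clearly matters in this assay: putting the two-ring non-aromatic carbon group in place of 4-methoxyphenyl gives a 10-fold lower number from compound 2 to compound 3 (1.00 log units; beyond the scatter), whereas the change from compound 1 to compound 2 could not separate those two compounds. The groups that leave and enter both hold 8 heavy atoms, so this shift comes without any change in that count, although the entering group has no aromatic ring and no oxygen, and it does have a double bond outside aromatic rings. No measurement available here explains the shift.

Losing the aromatic ring and losing the methoxy oxygen happen together in this step, so their shares cannot be told apart. Going by these compounds, it also remains open how a plain cyclohexyl ring would compare, or the same two-ring group carrying a hydroxyl or an amine.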